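Aryl substituent exchange on the thiosemicarbazone of the series

A few compounds are considered here, and "the series" means these few. Any claim that something is new, unique, unknown or untested is made for them only; others in the source may bear on it.

The three measured compounds share one core and differ only in the substituent on the phenyl attached to the carbon that carries the double bond to nitrogen. Compound 1 `CC1=CC[C@@H]([C@@](C)(O)CCCC(C)(C)NC(=S)N/N=C\c2ccc(C)cc2)CC1` carries a methyl there; in a functional assay on PCO3 cells (Homo sapiens) for cytotoxicity, read by sulforhodamine B assay (on this read-out higher numbers stand for weaker inhibition of growth and lower numbers for stronger inhibition of growth), compound 1 gives 45700 nM. Compound 2 `COc1ccc(/C=N\NC(=S)NC(C)(C)CCC[C@](C)(O)[C@@H]2CC=C(C)CC2)cc1` carries a methoxy; in this assay compound 2 gives 76100 nM. Compound 3 `CC1=CC[C@@H]([C@@](C)(O)CCCC(C)(C)NC(=S)N/N=C\c2ccc(N(C)C)cc2)CC1` carries a dimethylamino. For compound 3 this assay reports only a limit, > 100000 nM. Among the numbers shown there is the limit of > 100000 nM in this assay, at which 1 of the 3 values shown sits, and it is compound 3 that sits there, so compound 3 stands as a bound at the weak end rather than as a number.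

The measured steps: a 1.7-fold higher number from compound 1 to compound 2 (0.22 log units; within the scatter); an at least 2.1-fold higher number from compound 1 to compound 3 (0.34 log units; beyond the scatter); an at least 1.3-fold higher number from compound 2 to compound 3 (0.11 log units; that floor lies within the scatter).

Compound 4 `CC1=CC[C@@H]([C@@](C)(O)CCCC(C)(C)NC(=S)N/N=C\c2cccc([N+](=O)[O-])c2)CC1` is not yet measured. The change from compound 3 is 3-nitrophenyl in place of 4-(dimethylamino)phenyl on a carbon with a double bond to nitrogen. Going by the values given here, no measured step involves a nitro group, so the three exchanges on the aromatic carbon are the only guide, and they ranged from within the scatter to at most modest. The step from compound 3 is therefore expected to be small and its direction is uncertain, an at least 1.2-fold lower number from compound 3 to compound 4 (0.09 log units; that floor lies within the scatter). Compound 4 is expected to give about 80000 nM, within 30000 nM to 200000 nM.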

Compound 4, concentration for total growth inhibition: 20700 nM
Compound 4: the middle estimate sits 3.9-fold (0.59 log units) above what was measured; measured number outside the range, below it.
By their numbers in this assay, from the lowest: compound 4; then compounds 1 and 2 (each within the scatter of the next). At a limit, above all of these: compound 3.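

No earlier exchange at this position gave a number lower than that of compound 1 beyond the scatter, but 3-nitrophenyl on a carbon with a double bond to nitrogen does so in this assay, with a 2.2-fold lower number from compound 1 to compound 4 (0.34 log units; beyond the scatter). The same direction holds against the 4-methoxyphenyl compound, with a 3.7-fold lower number from compound 2 to compound 4 (0.57 log units; beyond the scatter), and against the 4-(dimethylamino)phenyl compound, with an at least 4.8-fold lower number from compound 3 to compound 4 (0.68 log units; beyond the scatter), where the step is only a floor. Compound 3 stands only as a limit of the assay: the limit of > 100000 nM in this assay, at which 1 of the 4 values shown sits.

The exchange to 3-nitrophenyl changes both the group and its place on the ring, and the compounds shown do not separate these two changes. As far as these compounds go, whether a nitrile or a carboxylic acid on the same ring would give a number like that of compound 4 remains open, as does how far the number can fall through changes to the aryl group alone.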